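The source may hold more compounds than are shown below. What is called first, only, known or untested is meant among the compounds shown, and "the series" means these compounds.

Measured compounds:
- compound 1, `CC(C)Oc1cccc(NC(=O)CN2CCC(c3cccc[n+]3[O-])CC2)c1`: 555 nM
- compound 2, `CSc1cccc(NC(=O)CN2CCC(c3cccc[n+]3[O-])CC2)c1`: 100 nM

Among the compounds with values here, in a functional assay on HEK293 cells for agonist activity at D(4) dopamine receptor (Homo sapiens), read by FLIPR (on this read-out lower numbers stand for an effect already at smaller amounts and higher numbers for an effect only at larger amounts of compound), compound 2 gives 100 nM, the lowest of the two numbers measured so far, and compound 1 gives 555 nM. Between them lies a single step, a 5.6-fold lower number from compound 1 to compound 2 (0.74 log units; beyond the scatter), which is the only measured change in this series. Compound 3, `O=C(CN1CCC(c2cccc[n+]2[O-])CC1)Nc1cccc(C(F)(F)F)c1`, differs from compound 2 in one place: trifluoromethyl in place of methylsulfanyl on an aromatic carbon. Within the data shown here, the one measured step bears on this change only loosely, since it also swaps a group on an aromatic carbon of the shared core and shows that such an exchange can shift this assay by a modest amount; but no measured compound carries a trifluoromethyl group, so its effect here is not known from the data. The expectation for compound 3 in this assay is therefore a number near that of compound 2, with a step of a 1.6-fold higher number from compound 2 to compound 3 (0.20 log units; within the scatter) that may stay within the scatter or move somewhat toward higher numbers. The estimate for compound 3 is 160 nM, with a range from 50 nM to 550 nM.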

Compound 3, half-maximal effective concentration: 76 nM
For compound 3 the middle estimate is 2.1-fold (0.32 log units) above the measured one, within the range that was stated.
By their numbers in this assay, from the lowest: compounds 3 and 2 (each within the scatter of the next); then compound 1.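

In this assay, the step of a 1.3-fold lower number from compound 2 to compound 3 (0.12 log units; within the scatter) shows that trifluoromethyl and methylsulfanyl cannot be told apart on this aromatic carbon, even though the count of heavy atoms goes from 2 to 4 and the count of hydrogen-bond acceptors from 1 to 0. The step of a 7.3-fold lower number from compound 1 to compound 3 (0.86 log units; beyond the scatter) is beyond the scatter, so isopropoxy now stands apart from two different groups at this place rather than from methylsulfanyl alone. No measurement in hand explains why trifluoromethyl and methylsulfanyl read alike or why isopropoxy reads differently from both.

Going by these compounds, how an amine, a carboxylic acid or a longer chain such as butoxy would read on this aromatic carbon remains open, and so does the reading with a plain hydrogen there. Also open, on these data alone, is whether the closeness of trifluoromethyl and methylsulfanyl would hold if another part of the shared core were changed, since all three compounds carry the same remainder.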